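Cytotoxicity notes: three compounds measured, compound 4 pending

The source may hold more compounds than are shown below. What is called first, only, known or untested is meant among the compounds shown, and "the series" means these compounds.

Measured values:
compound 1 `CC(C)COc1cccc(-c2ccc(C(=O)N(Cc3cccc(OCCCCCC(=O)O)c3)C(C)C)cc2)c1`: a limit of the assay, > 26000 nM
compound 2 `CC(C)N(Cc1cccc(OCCCCCC(=O)O)c1)C(=O)c1ccc(-c2ccco2)cc1`: a limit of the assay, > 26000 nM
compound 3 `COc1cccc(-c2ccc(C(=O)N(Cc3cccc(OCCCCCC(=O)O)c3)C(C)C)cc2)c1`: a limit of the assay, > 26000 nM

In an ADME assay on HepG2 cells (Homo sapiens) for cytotoxicity, read by CellTiter-Glo and resazurin assay, with a stated time of 72 h (a lower number here means that less compound is needed, a higher number that more compound is needed for the effect), every measured value is a limit rather than a number. Compound 1 therefore stands at the limit, as the limit of > 26000 nM in this assay, at which 3 of the 3 values shown sit, records. The steps a step that the two limits leave unreadable from compound 1 to compound 2, a step that the two limits leave unreadable from compound 1 to compound 3 and a step that the two limits leave unreadable from compound 2 to compound 3 give no readable size. Compound 4 `CC(C)N(Cc1cccc(OCCCCCC(=O)O)c1)C(=O)c1ccc(-c2cccc(Cl)c2)cc1` differs from compound 1 by chloro in place of isobutoxy on an aromatic carbon. Among the measured compounds shown here, no measured step covers this change, and the measured steps offer no size to carry over. Compound 4 is expected to remain at the limit, so the step that the limit leaves unreadable from compound 1 to compound 4 is expected to be unreadable or within scatter. Compound 4 is estimated at 40000 nM, with a range from 20000 nM to 100000 nM.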

Compound 4, half-maximal effective concentration: > 21900 nM
Compound 4 gave a limit, no number; the forecaster's own chance of this, stated with the estimate: 85%; the middle value does not contradict the limit.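

Compound 4 gives > 21900 nM, a limit of the assay, so its steps to compound 1, compound 2 and compound 3 cannot be read. The compounds shown leave open where any of the four has its half-maximal effective concentration in this assay, and whether exchanging chloro, methoxy, isobutoxy or furan-2-yl changes it.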